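Larger aryl replaces trifluoromethyl on a shared nitroimidazo core

The source may hold more compounds than are shown below. What is called first, only, known or untested is meant among the compounds shown, and "the series" means these compounds.

Compound 1 `O=[N+]([O-])c1cn2c(n1)OC[C@@H](OCC#Cc1ccc(C(F)(F)F)cn1)C2` and compound 2 `O=[N+]([O-])c1cn2c(n1)OC[C@@H](Oc1cccc(-c3ccc(OC(F)(F)F)cc3)n1)C2` share a core and were tested in a physicochemical assay for solubility, read by HPLC, at pH 7; on this read-out lower numbers stand for lower solubility and higher numbers for higher solubility. Compound 1 gives 8.4 ug/mL, the higher of the two numbers, while compound 2 gives 0.12 ug/mL, a gap beyond the usual scatter. Compound 3 `O=[N+]([O-])c1cn2c(n1)OC[C@@H](OCC#Cc1ccc(-c3ccc(OC(F)(F)F)cc3)cn1)C2` is not yet measured; it differs from compound 1 by 4-(trifluoromethoxy)phenyl in place of trifluoromethyl on an aromatic carbon. A downward step a 17-fold lower number from compound 1 to compound 3 (1.23 log units; beyond the scatter) is expected, because compound 2 gives 0.12 ug/mL while carrying the same 4-(trifluoromethoxy)phenyl. Compound 3 is estimated at 0.5 ug/mL, within 0.1 ug/mL to 2.5 ug/mL.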

Compound 3, solubility: 0.05 ug/mL
Beside the measured number, compound 3's estimate is 10-fold (1.00 log units) above it; measured number below the stated range.
By their numbers in this assay, from the lowest: compound 3; then compound 2; then compound 1.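

In this assay, among the compounds shown here, 4-(trifluoromethoxy)phenyl in place of trifluoromethyl on this aromatic carbon gives a 170-fold lower number from compound 1 to compound 3 (2.23 log units; beyond the scatter) and is the first comparison here in which only one place differs. The whole gap between these two compounds therefore belongs to this single change, and it is a large one, well beyond the scatter. Nothing shown here explains why the number falls so far. Open, as far as these compounds go, is what a plain phenyl, or a phenyl carrying an amine or a carboxylic acid, would give at this position.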